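The source may hold more compounds than are shown below. What is called first, only, known or untested is meant among the compounds shown, and "the series" means these compounds.

In a functional assay on HepG2 cells (Homo sapiens) for cytotoxicity, read by MTT assay, with a stated time of 48 h (on this read-out higher numbers stand for weaker inhibition and lower numbers for stronger inhibition), compound 1 `CC1=NN(C(=O)CSc2ccccc2)[C@@H](c2cc(Br)cc(Br)c2O)C1` gives 10400 nM and compound 2 `O=C(CSc1ccc([N+](=O)[O-])cc1)N1N=C(c2cc3ccccc3oc2=O)C[C@@H]1c1ccccc1C(F)(F)F` gives 7700 nM as its number, and these two values lie within the usual scatter of each other. Compound 3 `O=C(CSc1ccc(Br)cc1)N1N=C(c2cc3ccccc3oc2=O)C[C@@H]1c1ccccc1C(F)(F)F` has not been measured yet. It differs from compound 2 at one place, with bromo in place of nitro on an aromatic carbon, para to a large group (bromo in place of nitro on an aromatic carbon). Among the measured compounds shown here, no measured pair shows this change. In this assay no step beyond the scatter is expected, and the estimated step (a 1.0-fold higher number from compound 2 to compound 3 (0.02 log units; within the scatter)) stays small. The expected value for compound 3 is 8000 nM with a range from 3500 nM to 18000 nM around it.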

Compound 3, half-maximal inhibitory concentration: 17900 nM
Compound 3: the middle estimate sits 2.2-fold (0.35 log units) below what was measured, and the stated range covers the measured number.
By their numbers in this assay, from the lowest: compounds 2, 1 and 3 (each within the scatter of the next, the first and the last beyond it).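

In this assay, putting bromo in place of nitro on the six-membered aromatic ring gives a 2.3-fold higher number from compound 2 to compound 3 (0.37 log units; beyond the scatter) and leaves the rest of the structure unchanged. This first single-place comparison shows that a modest change in the number can come from this position alone. No measurement shown gives a reason for the step. On these data alone, how an amine or a carboxylic acid at the same place would read remains open, as does whether the same change would give a similar step on a different core.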